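The compounds below may be only part of what the source reports. "The series", "measured", "known", "first", "only" and "open" are said of these compounds alone.

Measured so far in a functional assay on MCF7 cells (Homo sapiens) for inhibition, read by MTT assay, with a stated time of 48 h; a lower number here means a stronger inhibitor, a higher number a weaker inhibitor:
compound 1 (`COc1ccc(C(c2c[nH]c3ccc(Br)cc23)c2c[nH]c3ccc(Br)cc23)cc1`) gives 2300 nM
compound 2 (`COc1cccc(C(c2c[nH]c3ccc(Br)cc23)c2c[nH]c3ccc(Br)cc23)c1OC`) gives 89000 nM
compound 3 (`COc1ccc(C(c2c[nH]c3ccc(Br)cc23)c2c[nH]c3ccc(Br)cc23)cc1OC`) gives 7800 nM

Compound 3 stands in the middle, with the number of compound 1 lower and that of compound 2 higher. Next comes compound 4 (`CN(C)c1ccc(C(c2c[nH]c3ccc(Br)cc23)c2c[nH]c3ccc(Br)cc23)cc1`), with this change (4-(dimethylamino)phenyl in place of 3,4-dimethoxyphenyl on a saturated chain carbon bound to two aromatic carbons). Like compound 4, compound 1 carries one group on that ring. The step adding a methoxy (a 3.4-fold higher number from compound 1 to compound 3 (0.53 log units; beyond the scatter)) was modest. The large steps (a 39-fold higher number from compound 1 to compound 2 (1.59 log units; beyond the scatter)) and (an 11-fold lower number from compound 2 to compound 3 (1.06 log units; beyond the scatter)) involve 2,3-dimethoxyphenyl, absent from compound 4, and count for less. Among the compounds with values here, no measured compound carries 4-(dimethylamino)phenyl, so the expectation is loose: a modest step towards a lower number in this assay is expected (a 2.6-fold lower number from compound 3 to compound 4 (0.41 log units; beyond the scatter)). The estimate for compound 4 is 3000 nM (expected range 800 nM to 12000 nM).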

Compound 4, half-maximal inhibitory concentration: 24900 nM
Compound 4: the middle estimate sits 8.3-fold (0.92 log units) below what was measured; the measured number lies above the stated range.
By their numbers in this assay, from the lowest: compound 1; then compound 3; then compound 4; then compound 2.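

In this assay, this position does not tolerate every single group on the ring equally: dimethylamino in place of methoxy costs a large step (an 11-fold higher number from compound 1 to compound 4 (1.03 log units; beyond the scatter)). 4-(dimethylamino)phenyl also falls behind 3,4-dimethoxyphenyl (a 3.2-fold higher number from compound 3 to compound 4 (0.50 log units; beyond the scatter)) but stays ahead of 2,3-dimethoxyphenyl (a 3.6-fold lower number from compound 2 to compound 4 (0.55 log units; beyond the scatter)). No evidence is available to account for these differences.

Open, on these data alone, is whether the loss follows dimethylamino specifically or extends to other nitrogen groups, such as a primary amine or morpholine. A hydroxyl or a halogen on that ring also remains to be compared with methoxy.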